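A few compounds are considered here, and "the series" means these few. Any claim that something is new, unique, unknown or untested is made for them only; others in the source may bear on it.

In a functional assay on MCF7 cells (Homo sapiens) for antiproliferative activity, read by sulforhodamine B assay, with a stated time of 72 h (a lower number here means a stronger inhibitor, a higher number a weaker inhibitor), compound 1 `O=C(Cn1nc(-c2ccccc2)c2ccccc2c1=O)Nc1ccccc1` gives 43000 nM, compound 2 `O=C(Cn1nc(-c2ccccc2)c2ccccc2c1=O)Nc1ccc(Cl)cc1` gives 33000 nM, and compound 3 `O=C(Cn1nc(Cc2ccccc2)c2ccccc2c1=O)Nc1ccccc1` gives 36000 nM. Compound 3 therefore sits level with the other two, as all three values lie within the usual scatter of one another. Compound 4 `O=C(Cn1nc(Cc2ccccc2)c2ccccc2c1=O)Nc1ccccc1Cl` differs from compound 3 in one place: chloro in place of hydrogen on an aromatic carbon. This puts chloro in place of hydrogen on an aromatic carbon, ortho to a large group. Within the data shown here, the one measured step of this kind is a 1.3-fold lower number from compound 1 to compound 2 (0.11 log units; within the scatter), and the other measured step, a 1.2-fold lower number from compound 1 to compound 3 (0.08 log units; within the scatter), is also small. Both stay within the scatter, so no step beyond the scatter is expected in this assay. The estimated step is a 1.2-fold lower number from compound 3 to compound 4 (0.08 log units; within the scatter). For compound 4 the expected value is 30000 nM, with an estimated range from 14000 nM to 62000 nM.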

Compound 4, half-maximal inhibitory concentration: 89000 nM
The estimate for compound 4 lay 3.0-fold (0.47 log units) below the measured number, outside the stated range (above it).
By their numbers in this assay, from the lowest: compounds 2, 3 and 1 (each within the scatter of the next); then compound 4.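

Chloro ortho to a large group brings a 2.5-fold higher number from compound 3 to compound 4 (0.39 log units; beyond the scatter), the first step in this assay to clear the scatter, and it points towards weaker inhibition. Chloro in place of hydrogen therefore carries no single fixed effect across these compounds, as the two cases differ in both the core and the place of the chloro: the same change on two cores in this assay, a 1.3-fold lower number (0.11 log units; within the scatter) from compound 1 to compound 2 and a 2.5-fold higher number (0.39 log units; beyond the scatter) from compound 3 to compound 4, 3.2-fold (0.51 log units) apart, beyond the scatter of two such steps.

On these data alone, whether this loss belongs to the position, the core or both stays open. As far as these compounds go, it is also open whether fluoro or methoxy at this same position would raise the number as chloro does.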